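Benzyl to 3-methylbenzyl: expectation for compound 3

A few compounds are considered here, and "the series" means these few. Any claim that something is new, unique, unknown or untested is made for them only; others in the source may bear on it.

Measured in a functional assay on the whole organism with Mus musculus as the target, in the maximal electroshock model; a lower number here means that less compound is needed, a higher number that more compound is needed for the effect:
- Compound 1 `C[C@@H](NCc1ccc(OCc2ccccc2)cc1)C(N)=O`: 17.1 mg/kg
- Compound 2 `CNC(=O)[C@@H](CO)NCc1ccc(OCc2ccccc2)cc1`: 22.8 mg/kg

In this assay compound 2 gives 22.8 mg/kg, within the scatter of compound 1 at 17.1 mg/kg, so these two numbers set no order.

Compound 3 `CNC(=O)[C@@H](CO)NCc1ccc(OCc2cccc(C)c2)cc1` keeps the core of compound 2 and carries a single change, (methyl in place of hydrogen on an aromatic carbon). This is methyl in place of hydrogen on an aromatic carbon, or benzyl to 3-methylbenzyl.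

Among the compounds with values here, only one measured step is available, a 1.3-fold higher number from compound 1 to compound 2 (0.12 log units; within the scatter). It lies within the scatter, but it concerns the group on the amine nitrogen, not the aromatic ring, so it bears on this change only indirectly. Within the data shown here, no measured compound carries a methyl on the ring, which leaves the size and direction of the change without direct support.

The expectation therefore starts from compound 2 at 22.8 mg/kg, and no step beyond the scatter is expected in this assay. The expected step is a 1.1-fold higher number from compound 2 to compound 3 (0.02 log units; within the scatter). For compound 3 the estimated value is 24 mg/kg, with an expected range of 11 mg/kg to 52 mg/kg.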

Compound 3, dose for half-maximal effect: 30.6 mg/kg
The estimate for compound 3 lay 1.3-fold (0.11 log units) below the measured number; measured number inside the range.
By their numbers in this assay, from the lowest: compounds 1, 2 and 3 (each within the scatter of the next).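

The ring of the benzyl group now has its first measured substitution: in this assay the change from benzyl to 3-methylbenzyl gives (a 1.3-fold higher number from compound 2 to compound 3 (0.13 log units; within the scatter)). Within the data shown here, the earlier pair spoke only to the group on the amine nitrogen, so this is the first reading at the ring, and it shows that this position takes one added carbon with no step beyond the scatter. No measured data accompany this step that could speak to a cause.

A single methyl at one ring position says little about other groups there, and a chlorine, a methoxy or a trifluoromethyl in the same place could still give a step of a different size or direction from compound 2. On these data alone, it also remains open whether methyl would read the same way on other aromatic carbons of that ring, or on the core of compound 1, which carries 1-carbamoylethyl on the amine nitrogen.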